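Swapping a guanidine for an amide on a thiazole core

The source may hold more compounds than are shown below. What is called first, only, known or untested is meant among the compounds shown, and "the series" means these compounds.

Compound 1 `COc1ccc(-c2nc(/N=C(\N)NC(C)C)sc2-c2ccc(OC)cc2)cc1`: 9.1 uM
Compound 2 `COc1ccc(-c2nc(/N=C(\N)N3CCOCC3)sc2-c2ccc(OC)cc2)cc1`: 66 uM
Compound 3 `COc1ccc(-c2nc(CN)sc2-c2ccc(OC)cc2)cc1`: 7.7 uM

These three compounds share a core carrying two 4-methoxyphenyl groups and were tested in a functional assay (aorta) with Rattus norvegicus as the target; on this read-out lower numbers stand for an effect already at smaller amounts and higher numbers for an effect only at larger amounts of compound. Compound 2 stands with the highest number of the three: the step of a 7.3-fold higher number from compound 1 to compound 2 (0.86 log units; beyond the scatter) and the step of an 8.6-fold lower number from compound 2 to compound 3 (0.93 log units; beyond the scatter) both set it apart, while compound 1 and compound 3 sit within the scatter of each other, as the step of a 1.2-fold lower number from compound 1 to compound 3 (0.07 log units; within the scatter) shows.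

Compound 4 `COc1ccc(-c2nc(C(=O)N3CCOCC3)sc2-c2ccc(OC)cc2)cc1` keeps the morpholine ring of compound 2 but changes what joins it to the core: a group of 8 heavy atoms (5 carbon, 1 nitrogen, 2 oxygen; one six-membered non-aromatic ring with 2 hetero atoms) in place of a group of 9 heavy atoms (5 carbon, 3 nitrogen, 1 oxygen; one six-membered non-aromatic ring with 2 hetero atoms), on an aromatic carbon. The two measured steps that bear on this both start or end at compound 2, and both are modest and point away from it. Neither tells directly what an amide in place of the guanidine does, so the expectation stays wide. Compound 4 is expected to give 50 uM in this assay, with a range from 12 uM to 200 uM. The estimated step is then a 1.3-fold lower number from compound 2 to compound 4 (0.12 log units; within the scatter), which is not beyond the scatter.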

Compound 4, concentration for half-maximal effect: < 100 uM
Compound 4 ended at the assay's limit; the forecaster's own chance of this, stated with the estimate: 25%; the middle value does not contradict the limit.
By their numbers in this assay, from the lowest: compounds 3 and 1 (each within the scatter of the next); then compound 2.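

In this assay compound 4 gives < 100 uM, which is a limit of the assay and not a number. Its steps to compound 1, compound 2 and compound 3 therefore cannot be read. On these data alone, whether (morpholin-4-yl)carbonyl gives a lower or higher number than the group it replaces in compound 2 stays open.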